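The source may report more compounds than this note shows. Statements on the series, on what has been measured and on what is new or still open speak of the compounds shown alone.

Measured so far:
compound 1, `COC(=O)c1cc(=O)c2c(OC)cc(OC)cc2[nH]1`: in an ADME assay on BJ cells (Homo sapiens) for antiproliferative activity, with a stated time of 72 h (on this read-out higher numbers stand for an effect only at larger amounts of compound and lower numbers for an effect already at smaller amounts), compound 1 gives > 34400 nM
compound 2, `COc1ccc(-c2cc(=O)c3c(OC)cc(OC)cc3n2S(=O)(=O)c2ccc([N+](=O)[O-])cc2)cc1`: in this assay compound 2 gives > 29300 nM

Both values are limits of this assay rather than numbers. Compound 1 sits at the limit of > 34400 nM in this assay, at which 1 of the 2 values shown sits. Compound 2 sits at the limit of > 29300 nM in this assay, at which 1 of the 2 values shown sits. Since both values shown are limits, compound 2 cannot be ranked against compound 1; all that the numbers show is that neither compound reaches a measurable half-maximal effective concentration within the tested range.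

Compound 3, `COc1ccc(-c2cc(=O)c3c(OC)cc(OC)cc3n2S(=O)(=O)c2c(F)c(F)c(F)c(F)c2F)cc1`, differs from compound 2 in one place: 2,3,4,5,6-pentafluorophenyl in place of 4-nitrophenyl on a sulfonyl sulfur. For the measured compounds named here, no step between two measured compounds exists, so no direction for this change can be read from the data. The working expectation is that the step from compound 2 to compound 3 in this assay is a step that the limit leaves unreadable from compound 2 to compound 3, none beyond the usual scatter, with compound 3 most likely again reported only as a limit. Compound 3 is therefore estimated at 30000 nM, with a range from 10000 nM to 60000 nM.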

Compound 3, half-maximal effective concentration: > 34400 nM
Compound 3: only a limit was reported; the forecaster's own chance of this, stated with the estimate: 85%; middle value at least 1.1-fold (0.05 log units) away from the limit.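

In this assay compound 3 gives > 34400 nM, which is a limit. Compound 2 gives > 29300 nM, also a limit. No step can be read between compound 2 and compound 3 from these two limits. The compounds shown leave open whether any group on the sulfonyl sulfur gives a measurable half-maximal effective concentration in this assay.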